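The source may hold more compounds than are shown below. What is called first, only, known or untested is meant among the compounds shown, and "the series" means these compounds.

In a functional assay on A549 cells (Homo sapiens) for cytotoxicity, read by MTT assay, with a stated time of 72 h (on this read-out higher numbers stand for weaker inhibition and lower numbers for stronger inhibition), compound 1 `Cc1cc(=O)n(-c2ccccc2C(F)(F)F)nc1C(=O)Nc1ccc(Oc2ncnc3ccsc23)cc1` gives 8850 nM, compound 2 `Cc1cc(=O)n(-c2ccc(F)cc2)nc1C(=O)Nc1ccc(Oc2ncnc3ccsc23)cc1` gives 2360 nM, and compound 3 `Cc1cc(=O)n(-c2ccc(F)c(F)c2)nc1C(=O)Nc1ccc(Oc2ncnc3ccsc23)cc1` gives 8180 nM.

The cores of compound 2 and compound 1 differ by 2-(trifluoromethyl)phenyl in place of 4-fluorophenyl on an aromatic nitrogen. From compound 2 to compound 3 the change is fluoro in place of hydrogen on an aromatic carbon, and it made a 3.5-fold higher number from compound 2 to compound 3 (0.54 log units; beyond the scatter). Compound 4 `Cc1cc(=O)n(-c2ccccc2C(F)(F)F)nc1C(=O)Nc1ccc(Oc2ncnc3ccsc23)c(F)c1` has not yet been measured; it carries the same kind of change from compound 1, (fluoro in place of hydrogen on an aromatic carbon). The surroundings are not identical: in compound 4 the entering fluoro is ortho to a large group, whereas in compound 3 it is ortho to a fluoro group (1 heavy atom); in both it is meta to a large group. Because a 3.5-fold higher number from compound 2 to compound 3 (0.54 log units; beyond the scatter) weakened inhibition in this assay, a step of similar size is expected from compound 1 to compound 4, a 1.8-fold higher number from compound 1 to compound 4 (0.26 log units; within the scatter). Compound 4 is therefore estimated at 16000 nM, expected to fall between 5000 nM and 45000 nM.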

Compound 4, half-maximal inhibitory concentration: 4680 nM
For compound 4 the middle estimate is 3.4-fold (0.53 log units) above the measured one, outside the stated range (below it).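

In this assay the added fluoro gives a 1.9-fold lower number from compound 1 to compound 4 (0.28 log units; within the scatter), so compound 4 cannot be told apart from compound 1. The same change therefore did not carry over from one core to the other with a similar effect: the same change on two cores in this assay, a 3.5-fold higher number (0.54 log units; beyond the scatter) from compound 2 to compound 3 and a 1.9-fold lower number (0.28 log units; within the scatter) from compound 1 to compound 4, 6.6-fold (0.82 log units) apart, beyond the scatter of two such steps. What lies behind this gap is not shown: the fluoro enters different surroundings in the two pairs, and each pair gives only a single example of the change.

Going by these compounds, it remains open whether the same fluoro placement on the core of compound 2 would match the result seen for compound 4. Also open, on these data alone, is how a chloro, a methoxy or an amine would fare at that aromatic carbon in place of fluoro.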